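A few compounds are considered here, and "the series" means these few. Any claim that something is new, unique, unknown or untested is made for them only; others in the source may bear on it.

Measured compounds:
compound 1, `O=C1C[C@H](O)C[C@@H](/C=C/c2c(Cl)cc(Cl)cc2-c2ccccc2)O1` — 80 nM
compound 2, `Cc1cc(C)c(/C=C/[C@@H]2C[C@@H](O)CC(=O)O2)c(-c2ccc(F)cc2)c1` — 13 nM
compound 3, `O=C1C[C@H](O)C[C@@H](/C=C/c2ccccc2-c2ccccc2)O1` — 3000 nM

In an assay for inhibition of 3-hydroxy-3-methylglutaryl-coenzyme A reductase (Rattus norvegicus) (on this read-out higher numbers stand for weaker inhibition and lower numbers for stronger inhibition), compound 1 stands second highest of the three numbers: compound 2 lies well below it, beyond the scatter, and compound 3 lies far above it, also beyond the scatter. Compound 4, `O=C1C[C@H](O)C[C@@H](/C=C/c2c(Cl)cc(Cl)cc2-c2cccc(F)c2)O1`, has not been measured in this assay. It differs from compound 1 in one place: fluoro in place of hydrogen on an aromatic carbon. Going by the values given here, no measured pair shows this change on its own, so its size is not known here. Compound 2, which also carries a fluorine on its pendant ring, gives the lowest number of the three, but its core substitution also differs. The step is expected to be small, within the scatter or a slight decrease, as a 1.3-fold lower number from compound 1 to compound 4 (0.12 log units; within the scatter). Compound 4 is estimated at 60 nM, in the range 20 nM to 180 nM.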

Compound 4, half-maximal inhibitory concentration: 70 nM
For compound 4 the middle estimate is 1.2-fold (0.07 log units) below the measured one, within the range that was stated.
By their numbers in this assay, from the lowest: compound 2; then compounds 4 and 1 (each within the scatter of the next); then compound 3.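

In this assay, going by these compounds alone, fluoro in place of hydrogen on an aromatic carbon, meta to a large group, gives a 1.1-fold lower number from compound 1 to compound 4 (0.06 log units; within the scatter) and so is the first direct reading of this change. On the core of compound 1, phenyl to 3-fluorophenyl leaves the number within the scatter, so this position tolerates fluoro. Nothing at hand explains the size of this step.

Open, from the compounds shown here alone, is whether other groups at this carbon, such as methoxy, an amine or a carboxylic acid, are tolerated as well. Also open, going by these compounds, is whether fluoro at other carbons of this ring gives a similar step.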